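A few compounds are considered here, and "the series" means these few. Any claim that something is new, unique, unknown or untested is made for them only; others in the source may bear on it.

Measured so far in an assay on cell membranes for displacement of a labelled ligand from corticotropin-releasing factor receptor 1 (Rattus norvegicus); on this read-out higher numbers stand for weaker inhibition and lower numbers for stronger inhibition:
Compound 1 `CCN(CC)c1nc(C)nc2c(-c3ccc(OC)c(C)c3C)c(C)nn12`: 38.6 nM
Compound 2 `CCN(CCC#N)c1nc(C)nc2c(-c3c(C)cc(OC)cc3OC)c(C)nn12`: 2.48 nM
Compound 3 `COc1ccc(-c2c(C)nn3c(N4CCCC4)nc(C)nc23)c(C)c1`: 80.7 nM

Of these three, compound 2 gives the lowest number, and its gaps to compound 1 and to compound 3 both lie beyond the usual scatter, so it is the strongest inhibitor of the set. Compound 4 `CCCC(C)Nc1nc(C)nc2c(-c3c(C)cc(OC)cc3OC)c(C)nn12` has not yet been measured. It differs from compound 2 in one place: (1-methylbutyl)amino in place of (2-cyanoethyl)(ethyl)amino on an aromatic carbon. Going by the values given here, no pair of measured compounds shows this change, so there is nothing to gauge it against directly. A modest weakening is expected, a step that may just pass the scatter but stays far short of the gaps between compound 2 and the others. The step expected is a 2.4-fold higher number from compound 2 to compound 4 (0.38 log units; beyond the scatter). Compound 4 is therefore expected to give about 6 nM in this assay, within a range from 1.5 nM to 25 nM.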

Compound 4, half-maximal inhibitory concentration: 2.14 nM
Estimate against measurement, compound 4: 2.8-fold (0.45 log units) above; measured number inside the range.
By their numbers in this assay, from the lowest: compounds 4 and 2 (each within the scatter of the next); then compound 1; then compound 3.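

Putting (1-methylbutyl)amino in place of (2-cyanoethyl)(ethyl)amino on the aromatic carbon between two ring nitrogen atoms gives, in this assay, a 1.2-fold lower number from compound 2 to compound 4 (0.06 log units; within the scatter) and leaves the two compounds indistinguishable. The position therefore accepts a swap that removes the nitrile and brings in a hydrogen-bond donor, with no clear change in the number. Nothing measured here explains this match. Still open, on these data alone, is whether a shorter chain such as ethylamino would do the same at this position. A morpholine ring there is also untested among the compounds shown.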